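Hydrazone glycosides: cyclohexyl in place of 4-methoxyphenyl

The source may report more compounds than this note shows. Statements on the series, on what has been measured and on what is new or still open speak of the compounds shown alone.

Measured compounds:
compound 1 `O=C(N/N=C/c1ccc(F)cc1)c1ccc(O[C@@H]2O[C@H](CO)[C@@H](O)[C@H](O)[C@H]2O)cc1` gives 9.91% in a functional assay on MDA-MB-231 cells (Homo sapiens) for inhibition, read by MTT assay, with a stated time of 24 h, tested at 100 uM; a higher number here means more inhibition at the concentration tested (going by the name of the read-out), a lower number less inhibition
compound 2 `COc1ccc(/C=N/NC(=O)c2ccc(O[C@@H]3O[C@H](CO)[C@@H](O)[C@H](O)[C@H]3O)cc2)cc1` gives 11.3% in this assay

Among the compounds with values here, compound 2 holds the higher of the two numbers, but its nearest neighbour, compound 1, lies within the scatter of it, the only measured step being a number 1.4 percentage points higher from compound 1 to compound 2 (within the scatter). Compound 3 `O=C(N/N=C/C1CCCCC1)c1ccc(O[C@@H]2O[C@H](CO)[C@@H](O)[C@H](O)[C@H]2O)cc1` differs from compound 2 by cyclohexyl in place of 4-methoxyphenyl on a carbon with a double bond to nitrogen. Within the data shown here, the single measured step concerns a substituent on the aromatic ring, not its replacement by a saturated ring, so it bears only loosely on this change; it was within the scatter. With both measured values low, no step beyond the scatter is expected in this assay, and the estimated step is a number 2.3 percentage points lower from compound 2 to compound 3 (within the scatter). Compound 3 is therefore expected to give 9%, within 1% to 20%.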

Compound 3, a percentage reported as inhibition, at one concentration (the size of the read-out at that concentration, not a potency): 0.88%
Compound 3: middle estimate off by 8.1 percentage points, on the high side; the whole stated range lies above it.
By their numbers in this assay, from the lowest: compounds 3, 1 and 2 (each within the scatter of the next, the first and the last beyond it).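

In this assay, within the data shown here, replacing the aromatic ring on the carbon with a double bond to nitrogen gives the first step beyond the scatter (a number 10.4 percentage points lower from compound 2 to compound 3 (beyond the scatter)), whereas the earlier methoxy-for-fluoro change did not. The same replacement starting from 4-fluorophenyl stays within the scatter (a number 9 percentage points lower from compound 1 to compound 3 (within the scatter)), so the effect is not established across both aryl compounds. Nothing available explains the step.

Still open, from the compounds shown here alone, is how a pyridine ring or a straight butyl chain would read at this carbon. Also open, going by these compounds, is whether any group here lifts inhibition far above that of compound 2.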